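Swapping the Amine Side Chain in a Triazole Series

A few compounds are considered here, and "the series" means these few. Any claim that something is new, unique, unknown or untested is made for them only; others in the source may bear on it.

The three compounds measured so far, with their values in an assay on nucleic acid for inhibition of Nucleic Acid, read by fluorescence, tested at 100 uM; on this read-out higher numbers stand for more inhibition at the one concentration tested (going by the name of the read-out) and lower numbers for less inhibition:

compound 1, `CN(Cc1cn(C2CCCCC2OC(=O)c2ccccc2)nn1)CC1CCCCC1`, gives 32%
compound 2, `CN(CCCc1ccccc1)Cc1cn(CC(O)COC(=O)NCc2ccccc2)nn1`, gives 79%
compound 3, `CN(Cc1cn(C2CCCCC2OC(=O)COc2ccccc2)nn1)CC1CCCCC1`, gives 37%

Compound 3 stands second of these three numbers. Its nearest neighbour is compound 1, which lies a little lower, and the gap between them is within the scatter of repeated measurements. Compound 2 lies far higher, beyond the scatter. Among the measured compounds shown here, the only single-point step on record, a number 5 percentage points higher from compound 1 to compound 3 (within the scatter), touches the ester part of the molecule and is itself within the scatter.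

Compound 4, `CC(C)CCN(C)Cc1cn(C2CCCCC2OC(=O)COc2ccccc2)nn1`, is not yet measured. It differs from compound 3 in one place: isobutyl in place of cyclohexyl on a saturated chain carbon bound to an amine nitrogen. For the measured compounds named here, this part of the molecule is untouched by any measured step, so no step on record speaks directly to it; the amine substituent of compound 2 is also different, but compound 2 differs in several places at once and gives no clean comparison. With nothing to point to a change, the expectation for compound 4 is a step of a number 1 percentage points lower from compound 3 to compound 4 (within the scatter), which is no change beyond the scatter. The estimate for compound 4 in this assay is therefore 36%, between 16% and 56%.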

Compound 4, a percentage reported as inhibition, at one concentration (the size of the read-out at that concentration, not a potency): 59%
Compound 4: the middle estimate sits 23 percentage points below what was measured; measured number above the stated range.
By their numbers in this assay, from the lowest: compounds 1 and 3 (each within the scatter of the next); then compound 4; then compound 2.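

Among the compounds shown here, this is the first sign that the amine side chain matters. In this assay, for the compounds shown here, isobutyl in place of cyclohexyl on a saturated chain carbon bound to an amine nitrogen gives a number 22 percentage points higher from compound 3 to compound 4 (beyond the scatter), whereas the only earlier single-point step, at the ester end of the molecule, gives a number 5 percentage points higher from compound 1 to compound 3 (within the scatter). The change takes away the six-membered carbon ring and leaves an open, branched chain with fewer carbons, while the count of hydrogen-bond donors and acceptors stays the same, and nothing available explains why this raises the number.

This one swap changes the ring and the carbon count together, so it cannot show which of the two matters; a cyclopentyl group or a straight butyl chain at the same place would help to separate them. It also leaves open whether the isobutyl side chain would give a similar step with the other ester, the one carrying phenyl on the carbonyl carbon in compound 1, or whether the step belongs to the phenoxymethyl ester alone.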